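Notes on the side-chain ring change from compound 2

A few compounds are considered here, and "the series" means these few. Any claim that something is new, unique, unknown or untested is made for them only; others in the source may bear on it.

Compound 1 `CN(C)CCn1cccc1/C=N/NC(=O)Nc1ccc(Oc2ccnc3[nH]ccc23)c(F)c1` gives "not active" (no number reported) as its result
Compound 2 `O=C(N/N=C/c1cccn1CCCN1CCCCC1)Nc1ccc(Oc2ccnc3[nH]ccc23)c(F)c1` gives 2850 nM as its result

Going by the values given here, in a functional assay on A549 cells (Homo sapiens) for antiproliferative activity, read by MTT assay, with a stated time of 72 h (on this read-out higher numbers stand for weaker inhibition and lower numbers for stronger inhibition), compound 2 (2850 nM) is the only compound with a number, so it has no measured neighbour to be ranked against. Compound 3 `CN1CCN(CCCn2cccc2/C=N/NC(=O)Nc2ccc(Oc3ccnc4[nH]ccc34)c(F)c2)CC1` is the next to be read. It differs from compound 2 by one change (4-methylpiperazin-1-yl in place of piperidin-1-yl on a saturated chain carbon, three bonds along the chain from an aromatic nitrogen): 4-methylpiperazin-1-yl in place of piperidin-1-yl on a saturated chain carbon, three bonds along the chain from an aromatic nitrogen. Among the compounds with values here, no measured step exists to size this change. The estimated step in this assay is small (a 1.2-fold higher number from compound 2 to compound 3 (0.09 log units; within the scatter)), with none expected beyond the scatter and no firm direction. Compound 1 ("not active" (no number reported)) leaves open that a result without a number is possible here. For compound 3 the expected value is 3500 nM (estimated range 1200 nM to 10000 nM).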

Compound 3, half-maximal inhibitory concentration: 2200 nM
Compound 3: middle estimate off by 1.6-fold (0.20 log units), on the high side; the measured number falls inside the stated range.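

In this assay, going by these compounds alone, the first measured change on a saturated chain carbon, three bonds along the chain from an aromatic nitrogen, gives a 1.3-fold lower number from compound 2 to compound 3 (0.11 log units; within the scatter). Compound 2 and compound 3 therefore cannot be told apart on this read-out, and this position accepts 4-methylpiperazin-1-yl in place of piperidin-1-yl without a step beyond the scatter. No measurement at hand accounts for this result.

Compound 1 has no number and differs from compound 2 in both the chain and the amine, so no step to it can be read, and the shown compounds do not separate these two parts. Also open, going by these compounds, is whether a morpholine ring or a longer chain carrying piperidin-1-yl would read any differently from compound 2 and compound 3.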